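This account rests on a few compounds, and the source may have more. Where it says the series, first, only, none or still open, it means among the compounds named here.

Working notes on the series, read in a functional assay on J774 cells (Mus musculus) for cytotoxicity, read by resazurin assay; a lower number here means a stronger inhibitor, a higher number a weaker inhibitor. Within the data shown here, compound 1 (`OCCCCCC(O)c1ccc(-c2ccc(Br)cc2)cc1`) gives 20000 nM, the higher of the two true numbers so far. The nearest value belongs to compound 3 (`OCCCCCC(O)c1ccc(-c2ccc(Cl)cc2Cl)cc1`), which gives a lower 8000 nM, a gap beyond the scatter. Compound 2 (`OCCCCCC(O)c1ccc(-c2cccc(Cl)c2)cc1`) reads > 100000 nM, which is a limit of the assay and not a number. The ceiling concerns this compound alone: the limit of > 100000 nM in this assay, at which 1 of the 3 values shown sits.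

Next is compound 4 (`OCCCCCC(O)c1ccc(-c2ccc(C(F)(F)F)cc2)cc1`), with trifluoromethyl in place of bromo on an aromatic carbon, para to a large group: trifluoromethyl in place of bromo on an aromatic carbon.

Among the measured compounds shown here, only one measured step bears on this place: an at least 5.0-fold higher number from compound 1 to compound 2 (0.69 log units; beyond the scatter). That step removes the 4-bromophenyl that compound 4 also alters, so the number can move with a change on this ring. It is a different change, however, and its size is only a bound. For the measured compounds named here, no measured step swaps bromo for trifluoromethyl, so the size of the step in this assay is expected to stay within the scatter, with no favoured direction. For compound 4 the expected step is no change at the digits printed from compound 1 to compound 4 (within the scatter). The estimated value for compound 4 is 20000 nM, with an expected range of 7000 nM to 60000 nM.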

Compound 4, half-maximal inhibitory concentration: 13000 nM
For compound 4 the middle estimate is 1.5-fold (0.19 log units) above the measured one; the range from low to high includes it.
By their numbers in this assay, from the lowest: compounds 3, 4 and 1 (each within the scatter of the next, the first and the last beyond it). At a limit, above all of these: compound 2.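

Trifluoromethyl in place of bromo on an aromatic carbon, para to a large group, gives a 1.5-fold lower number from compound 1 to compound 4 (0.19 log units; within the scatter) in this assay, so 4 heavy atoms can stand at this place in place of 1 with no change that can be told from the scatter. Compound 2 stands at a limit of the assay, so the earlier step on this ring gave only a bound, whereas this step is read between two true numbers and gives the first actual size for a change at this place. Nothing measured alongside these compounds explains why the two groups read alike.

Open, from the compounds shown here alone, is whether an amine or a carboxylic acid at this same place would stay within the scatter of bromo and trifluoromethyl, or would move the number as far as the change in compound 2 did. Also open is what a longer chain on the shared core would do to these readings, since the compounds shown all carry the same chain.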